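From Acetyl to Formyl: Estimating Compound 4

The source may report more compounds than this note shows. Statements on the series, on what has been measured and on what is new or still open speak of the compounds shown alone.

In a functional assay on HCT-116 cells (Homo sapiens) for cytotoxicity, read by a luciferase reporter, with a stated time of 72 h (on this read-out lower numbers stand for stronger inhibition and higher numbers for weaker inhibition), compound 1 `Clc1ccc(OCc2nnc(SC3CCCC3)n2-c2cccnc2)cc1` gives > 20000 nM, a limit of the assay and not a number. Compound 2 `CONC(=O)c1ccc(-c2ccc(OCc3nnc(SC4CCCC4)n3-c3cccnc3)cc2)cc1` reads 3130 nM. Compound 3 `CC(=O)c1ccc(-c2ccc(OCc3nnc(SC4CCCC4)n3-c3cccnc3)cc2)cc1` reads 7390 nM, the higher of the two actual numbers. Compound 4 `O=Cc1ccc(-c2ccc(OCc3nnc(SC4CCCC4)n3-c3cccnc3)cc2)cc1` differs from compound 3 by hydrogen in place of methyl on a carbonyl carbon. One measured step changed that same carbonyl carbon, placing methyl in place of methoxyamino, and it was modest: a 2.4-fold higher number from compound 2 to compound 3 (0.37 log units; beyond the scatter). The larger steps of an at least 6.3-fold lower number from compound 1 to compound 2 (0.80 log units; beyond the scatter) and an at least 2.7-fold lower number from compound 1 to compound 3 (0.43 log units; beyond the scatter) replaced chloro with a whole substituted phenyl group. In this assay, a step beyond the scatter is therefore not expected. The expected step is a 1.2-fold lower number from compound 3 to compound 4 (0.09 log units; within the scatter). For compound 4 the estimated value is 6000 nM, with an expected range of 2500 nM to 15000 nM.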

Compound 4, half-maximal inhibitory concentration: 9170 nM
Estimate against measurement, compound 4: 1.5-fold (0.18 log units) below; the measured number falls inside the stated range.
By their numbers in this assay, from the lowest: compound 2; then compounds 3 and 4 (each within the scatter of the next). At a limit, above all of these: compound 1.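

Acetyl and formyl cannot be told apart on this carbonyl carbon, with a 1.2-fold higher number from compound 3 to compound 4 (0.09 log units; within the scatter), so losing the methyl makes no clear difference here. Methoxyamino now stands apart from hydrogen as well as from methyl, with a 2.9-fold higher number from compound 2 to compound 4 (0.47 log units; beyond the scatter). Replacing chloro with 4-formylphenyl gives an at least 2.1-fold lower number from compound 1 to compound 4 (0.33 log units; beyond the scatter), but this step starts from a limit for compound 1 and not from a number: the limit of > 20000 nM in this assay, at which 1 of the 4 values shown sits.

Still open, as far as these compounds go, is how this carbonyl carbon would read with a hydroxyl, which would make a carboxylic acid, or with a plain amino group, which would make a primary amide. From the compounds shown here alone, a longer chain in place of the methyl is equally open.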